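A few compounds are considered here, and "the series" means these few. Any claim that something is new, unique, unknown or untested is made for them only; others in the source may bear on it.

Compounds in this set share a core bearing a hydroxyphenyl group, a chlorophenyl group and a third aromatic ring. Compound 1 is `Oc1ccc(-c2cc(-c3ccc(Cl)cc3)nc(-c3cccnc3)c2)cc1`; compound 3 is `Oc1ccc(-c2cc(-c3cccc(Cl)c3)nc(-c3ccccn3)c2)cc1`; compound 2 is `Oc1cccc(-c2cc(-c3ccncc3)nc(-c3cccc(Cl)c3)c2)c1`, for which no result is reported. In an ADME assay on HEK293 cells (Homo sapiens) for cytotoxicity, read by CCK-8 assay and cell counting, with a stated time of 2 days (a lower number here means a stronger inhibitor, a higher number a weaker inhibitor), compound 1 gives 27500 nM, and compound 3 gives 25400 nM. For compound 2 the entry in this assay is "not determined" (no result reported), so no number is available for it. Compound 1 therefore holds the higher of the two numbers available, but the gap to compound 3 lies within the scatter of repeated measurements, so the two stand together rather than apart.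

The next compound, compound 4, is `Oc1ccc(-c2cc(-c3ccc(Cl)cc3)nc(-c3cccs3)c2)cc1`. Relative to compound 1 the change is thiophen-2-yl in place of pyridin-3-yl on an aromatic carbon, at the place next to the ring nitrogen of the core and meta to both the 4-chlorophenyl group and the 4-hydroxyphenyl group. Among the compounds with values here, no step between two measured compounds is available for this exchange, so its size cannot be read from the series. Both measured compounds sit at much the same weak level in this assay, and a ring swap of this kind is expected to leave the number near that level, perhaps slightly lower. For compound 4 the estimate is 22000 nM, with a range from 10000 nM to 50000 nM, meaning an expected step of a 1.3-fold lower number from compound 1 to compound 4 (0.10 log units; within the scatter) that may not exceed the scatter.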

Compound 4, half-maximal inhibitory concentration: 4520 nM
The estimate for compound 4 lay 4.9-fold (0.69 log units) above the measured number; measured number below the stated range.
By their numbers in this assay, from the lowest: compound 4; then compounds 3 and 1 (each within the scatter of the next).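

In this assay the place next to the ring nitrogen of the core proves able to move the number: thiophen-2-yl in place of pyridin-3-yl gives a 6.1-fold lower number from compound 1 to compound 4 (0.78 log units; beyond the scatter). Within the data shown here, the earlier compounds offered no pair differing in one place, so their similar numbers said nothing about how far this position can shift the read-out, and this exchange provides the first single-place step. The step changes ring size and hetero atom together, as a six-membered aromatic ring with nitrogen gives way to a five-membered aromatic ring with sulfur, so it cannot assign the shift to either feature, and no measurement at hand accounts for it.

A furan-2-yl group, with oxygen in the five-membered ring, and a plain phenyl ring at this place would help separate the role of ring size from that of the hetero atom. Whether the shift persists with a 3-chlorophenyl group elsewhere on the shared core remains open, since the compounds shown offer no matching pair to test it.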